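The source may hold more compounds than are shown below. What is called first, only, known or untested is meant among the compounds shown, and "the series" means these compounds.

Measured in a functional assay on K562 cells (Homo sapiens) for cytotoxicity, read by MTT assay, with a stated time of 72 h (a lower number here means a stronger inhibitor, a higher number a weaker inhibitor), so far
- compound 1 `C=C1C(=O)[C@@]23C(=O)OC[C@]4(C(=O)CCC(C)(C)[C@H]4C=O)[C@@H]2CC[C@@H]1[C@H]3OC(=O)c1ccccc1` gives 1480 nM on the benzoate
- compound 2 `C=C1C(=O)[C@@]23C(=O)OC[C@]4(C(=O)CCC(C)(C)[C@H]4C=O)[C@@H]2CC[C@@H]1[C@H]3OC(=O)c1ccc(OC)cc1` gives 1650 nM on the methoxy analogue
- compound 3 `C=C1C(=O)[C@@]23C(=O)OC[C@]4(C(=O)CCC(C)(C)[C@H]4C=O)[C@@H]2CC[C@@H]1[C@H]3OC(=O)c1ccccc1F` gives 2860 nM on the fluoro analogue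

Compound 3 stands within the scatter of both others, with a 1.9-fold higher number from compound 1 to compound 3 (0.29 log units; within the scatter) and a 1.7-fold higher number from compound 2 to compound 3 (0.24 log units; within the scatter) as its steps. Compound 4 `C=C1C(=O)[C@@]23C(=O)OC[C@]4(C(=O)CCC(C)(C)[C@H]4C=O)[C@@H]2CC[C@@H]1[C@H]3OC(=O)c1ccc(Cl)cc1` carries 4-chlorophenyl in place of 2-fluorophenyl on a carbonyl carbon on a carbonyl carbon. Among the compounds with values here, no chloro compound has been measured. The nearest evidence is the aromatic substitutions, a 1.1-fold higher number from compound 1 to compound 2 (0.05 log units; within the scatter) and a 1.9-fold higher number from compound 1 to compound 3 (0.29 log units; within the scatter), both within the scatter. No step beyond the scatter is therefore expected in this assay here. The expected change is a 1.5-fold lower number from compound 3 to compound 4 (0.18 log units; within the scatter) and stays within the scatter. Compound 4 is estimated at 1900 nM with an expected range from 1000 nM to 3500 nM as a working figure.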

Compound 4, half-maximal inhibitory concentration: 1380 nM
Compound 4: the middle estimate sits 1.4-fold (0.14 log units) above what was measured; the range from low to high includes it.
By their numbers in this assay, from the lowest: compounds 4, 1, 2 and 3 (each within the scatter of the next, the first and the last beyond it).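

In this assay, within the data shown here, the change to 4-chlorophenyl on the carbonyl carbon gives the first step beyond the scatter, a 2.1-fold lower number from compound 3 to compound 4 (0.32 log units; beyond the scatter), though a modest one. The same group stays within the scatter of the other two aryl esters, with a 1.2-fold lower number from compound 2 to compound 4 (0.08 log units; within the scatter) and a 1.1-fold lower number from compound 1 to compound 4 (0.03 log units; within the scatter), so chloro, methoxy and hydrogen on the aromatic carbon are not told apart here. Nothing on hand accounts for the step.

The step swaps both the halogen and its place on the ring, so the two cannot be separated without 4-fluorophenyl or 2-chlorophenyl. From the compounds shown here alone, an aminophenyl or carboxyphenyl ester, or a longer chain in place of the aryl ring, remains open.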